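Furan to indole swap in the tetradecyl threonine amide series

The compounds below may be only part of what the source reports. "The series", "measured", "known", "first", "only" and "open" are said of these compounds alone.

Measured so far:
Compound 1 `CCCCCCCCCCCCNC(=O)[C@@H](NC(=O)c1ccco1)[C@@H](C)O` — in a functional assay on HepG2 cells (Homo sapiens) for cytotoxicity, read by MTT assay, with a stated time of 48 h (a lower number here means a stronger inhibitor, a higher number a weaker inhibitor), compound 1 gives 147000 nM.
Compound 2 `CCCCCCCCCCCCCCNC(=O)[C@@H](NC(=O)c1ccco1)[C@@H](C)O` — in this assay compound 2 is reported only as a limit, > 400000 nM.

Compound 2 carries ethyl in place of hydrogen on a saturated chain carbon, ten or more bonds along the chain from an amide-type nitrogen, relative to compound 1, and the step of an at least 2.7-fold higher number from compound 1 to compound 2 (0.43 log units; beyond the scatter) runs in the direction of a weaker inhibitor. Where compound 2 stands is set by the limit of > 400000 nM in this assay, at which 1 of the 2 values shown sits, so its own number is not known; it is the weaker of the two measured compounds, but by an unknown margin.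

Compound 3 `CCCCCCCCCCCCCCNC(=O)[C@@H](NC(=O)c1cc2ccccc2[nH]1)[C@@H](C)O` differs from compound 2 by 1H-indol-2-yl in place of furan-2-yl on a carbonyl carbon. Within the data shown here, no measured step touches this carbonyl substituent; the only measured step concerns the chain end and says nothing about exchanging the furan-2-yl group. The expectation for compound 3 therefore rests on compound 2 alone. Compound 3 is expected to give about 400000 nM, within a range of 150000 nM to 1000000 nM. The step of a number no higher from compound 2 to compound 3 (the limit leaves the size open) is thus expected to stay within the scatter, with a high chance that compound 3 is again reported only as a limit.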

Compound 3, half-maximal inhibitory concentration: 10500 nM
For compound 3 the middle estimate is 38-fold (1.58 log units) above the measured one; the measured number lies below the stated range.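

The carbonyl substituent is a position that moves the read-out strongly in this assay: 1H-indol-2-yl in place of furan-2-yl on a carbonyl carbon gives an at least 38-fold lower number from compound 2 to compound 3 (1.58 log units; beyond the scatter) and runs in the direction of a stronger inhibitor. Among these compounds, the earlier step, an at least 2.7-fold higher number from compound 1 to compound 2 (0.43 log units; beyond the scatter), touched only the chain end, so this is the first reading on the group at the carbonyl carbon, and with the chain held constant it shows that this single exchange is enough to bring a compound back to a measured number. From the compounds shown here alone, compound 2 enters this step only as a limit, so the true size of the step stays unknown: the limit of > 400000 nM in this assay, at which 1 of the 3 values shown sits.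

The exchange adds a six-membered aromatic ring of carbon only and also swaps the ring oxygen for a ring nitrogen bearing hydrogen, and these compounds do not separate the two changes; a benzofuran-2-yl or a pyrrol-2-yl group on the same carbonyl carbon would pull them apart. Going by these compounds, whether 1H-indol-2-yl gives a step of similar size on the shorter chain of compound 1 also stays open.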